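The compounds below may be only part of what the source reports. "The series", "measured", "known", "first", "only" and "open" are said of these compounds alone.

Working notes on the series

Three measured members: compound 1 `O=c1c(C2N=C(c3ccccc3)SS2)coc2cc(Cl)ccc12`, compound 2 `Cc1ccc2occ(C3N=C(c4ccccc4)SS3)c(=O)c2c1` and compound 3 `O=c1c(C2N=C(c3ccccc3)SS2)coc2ccc(F)cc12`, all run in a functional assay on COLO 205 cells (Homo sapiens) for inhibition, read by sulforhodamine B assay, with a stated time of 48 h; on this read-out higher numbers stand for weaker inhibition and lower numbers for stronger inhibition. Compound 1 gives 76700 nM in this assay. For compound 2 this assay returns only a limit, > 100000 nM. For compound 3 this assay likewise returns only a limit, > 100000 nM, so compound 3 has no number of its own and sits at the limit of > 100000 nM in this assay, at which 2 of the 3 values shown sit. For the measured compounds named here, the single one-point step among the measured compounds, a step that the two limits leave unreadable from compound 2 to compound 3, has both ends at that limit and yields no readable size, so no measured step gives a direction for substitution on the chlorine-free ring.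

Compound 4 `O=c1c(C2N=C(c3ccccc3)SS2)coc2cc(Cl)c(F)cc12` differs from compound 3 by chloro in place of hydrogen on an aromatic carbon. Going by the values given here, no measured pair covers a chloro entering, but compound 1 carries a chloro on the same ring and gives 76700 nM, a weak result. The two structural ends of the question, compound 1 and compound 3, both point to weak inhibition. Compound 4 is therefore expected to land close to the limit, with an estimate of 80000 nM and a range of 30000 nM to 200000 nM. The expected step from compound 3 is an at least 1.2-fold lower number from compound 3 to compound 4 (0.09 log units; that floor lies within the scatter), read against a starting limit and so itself uncertain in size; a reported limit for compound 4 is about as likely as a number.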

Compound 4, half-maximal inhibitory concentration: > 100000 nM
Compound 4: only a limit was reported; the forecaster's own chance of this, stated with the estimate: 50%; at least 1.2-fold (0.09 log units) between middle value and limit.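

With the chloro in place of hydrogen, ortho to a fluoro group, compound 4 also returns only a limit in this assay, so the step from compound 3 cannot be read and the chloro at this position shows no readable gain: the limit of > 100000 nM in this assay, at which 3 of the 4 values shown sit. For the compounds shown here, the fluoro in place of hydrogen gives the first step that has any readable size, an at least 1.3-fold higher number from compound 1 to compound 4 (0.11 log units; that floor lies within the scatter), but this is only a floor and it fixes no true size. Even so, the chloro-bearing core with a number of its own no longer yields one once the fluoro is present, so the chloro alone does not secure a measurable value in this series.

As far as these compounds go, the true sizes of both steps at this position remain open, since the values for compound 3 and compound 4 are limits and not numbers. Also open, from the compounds shown here alone, is whether a different group on this ring, such as an amine or a carboxylic acid in place of the chloro, would bring the read-out clear of the limit.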